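Methyl in place of fluoro on the double-bonded chain

This account rests on a few compounds, and the source may have more. Where it says the series, first, only, none or still open, it means among the compounds named here.

Compound 1 `C=C(C(=O)Nc1cc(Nc2nccc(-c3cn(C)c4ccccc34)n2)c(OC)cc1N(C)CCN(C)C)C(F)(F)F` and compound 2 `C=C(F)C(=O)Nc1cc(Nc2nccc(-c3cn(C)c4ccccc34)n2)c(OC)cc1N(C)CCN(C)C` share one core and differ only in the group on a double-bonded chain carbon bound to a carbonyl carbon. In a functional assay on A-431 cells (Homo sapiens) for antiproliferative activity, read by sulforhodamine B assay, with a stated time of 72 h (on this read-out lower numbers stand for stronger inhibition and higher numbers for weaker inhibition), compound 1 gives 11200 nM while compound 2 gives 2500 nM and so holds the lower of the two numbers. Going by the values given here, the gap between them is the only measured step at this place, a 4.5-fold lower number from compound 1 to compound 2 (0.65 log units; beyond the scatter) and it is modest. Compound 3 `C=C(C)C(=O)Nc1cc(Nc2nccc(-c3cn(C)c4ccccc34)n2)c(OC)cc1N(C)CCN(C)C` has not yet been measured and differs from compound 2 by one change, methyl in place of fluoro on a double-bonded chain carbon bound to a carbonyl carbon with methyl in place of fluoro at that same place. The measured step shows that the number responds to the group here, but it offers no direct reading for methyl. Methyl restores a carbon at this place, as trifluoromethyl has in compound 1 at 11200 nM and so a modest rise is expected, smaller than the measured step. The expected change is a 2.2-fold higher number from compound 2 to compound 3 (0.34 log units; beyond the scatter) and it points upward. Compound 3 is estimated at 5500 nM with an expected range from 2000 nM to 14000 nM in this assay until the measurement arrives.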

Compound 3, half-maximal inhibitory concentration: 5340 nM
The estimate for compound 3 lay 1.0-fold (0.01 log units) above the measured number, within the range that was stated.
By their numbers in this assay, from the lowest: compound 2; then compound 3; then compound 1.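

With compound 3 the position now carries three groups on the shared core, and methyl takes neither end of the order in this assay: it stands above fluoro (a 2.1-fold higher number from compound 2 to compound 3 (0.33 log units; beyond the scatter)) and below trifluoromethyl (a 2.1-fold lower number from compound 1 to compound 3 (0.32 log units; beyond the scatter)). Both steps are modest, yet each lies beyond the scatter, so the three groups separate into three distinct levels, and the two groups with a carbon at this place both give higher numbers than fluoro, with no compound shown going against that. Fluorine alone does not sort the series, since fluoro and trifluoromethyl both carry it and stand at opposite ends, while methyl carries none and falls in the middle; nothing given here offers an explanation for this order.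

The compounds shown do not tell where hydrogen, chlorine or a longer chain such as ethyl would fall at this place, nor whether a chain ending in an amine would leave the order intact. They also leave open whether the same order of fluoro, methyl and trifluoromethyl would hold on a different core or in other cells.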